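A few compounds are considered here, and "the series" means these few. Any claim that something is new, unique, unknown or untested is made for them only; others in the source may bear on it.

Working notes on the amide series in a physicochemical assay for solubility, read by nephelometry, measured as kinetic solubility, at pH 2, tested at 10 mg/mL; on this read-out lower numbers stand for lower solubility and higher numbers for higher solubility. The parent is compound 1, `Cc1ccnc(NC(=O)c2ccccc2C)c1`. In this assay, on these data alone, compound 1 gives > 100 ug/mL, which is a limit of the assay and not a number, so where compound 1 actually stands above that limit is unknown. Among the measured compounds shown here, its one measured partner is compound 2, `Cc1ccccc1C(=O)Nc1cc(C#N)ccn1`, which in this assay gives 50 ug/mL. For the measured compounds named here, the single step measured so far, an at least 2.0-fold lower number from compound 1 to compound 2 (0.30 log units; that floor lies within the scatter), is a cyano in place of methyl on an aromatic carbon, and its floor rests on (the limit of > 100 ug/mL in this assay, at which 1 of the 2 values shown sits).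

The compound now in question is compound 3, `Cc1ccnc(NC(=O)c2cccc(F)c2C)c1`. Against compound 1 it differs as follows: fluoro in place of hydrogen on an aromatic carbon. Going by the values given here, no measured step covers a change of this kind; the step from compound 1 to compound 2 concerns a different group at a different place and is only a loose guide. The expected step of a number no higher from compound 1 to compound 3 (the limit leaves the size open) is therefore put at none beyond the scatter, with the possibility that compound 3 again returns only the limit. Compound 3 is estimated at 100 ug/mL, expected within 40 ug/mL to 200 ug/mL.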

Compound 3, solubility: > 100 ug/mL
Compound 3: a limit, no number (the forecaster's own chance of this, stated with the estimate: 50%); the middle value sits exactly at the limit.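

In this assay, among the compounds shown here, compound 3 returns only a limit and not a number, as compound 1 does, so no step between the two can be read: the limit of > 100 ug/mL in this assay, at which 2 of the 3 values shown sit.

Where compound 1 and compound 3 actually stand past that limit, and whether fluoro in place of hydrogen on an aromatic carbon shifts the read-out at all, remains open.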